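Trifluoromethyl gives way to hydrogen on compound 3

The source may report more compounds than this note shows. Statements on the series, on what has been measured and on what is new or still open speak of the compounds shown alone.

Of the compounds shown here, three built on a shared core have so far been measured in a functional assay on A549 cells (Homo sapiens) for cytotoxicity, read by MTT assay, with a stated time of 68 h (a higher number here means a weaker inhibitor, a lower number a stronger inhibitor), and they do not all give a number. Compound 1 (`Cc1ccccc1-c1cccc(NC(=O)C(Cl)Cl)c1`) gives 9860 nM in this assay as its reading. Compound 3 (`O=C(Nc1cccc(-c2cccc(C(F)(F)F)c2)c1)C(Cl)Cl`) gives 18500 nM as its reading, and compound 1 is the nearest number to it, within the usual scatter of repeated measurements. Compound 2 (`O=C(Nc1cccc(-c2ccsc2)c1)C(Cl)Cl`) is reported only as a limit (> 50000 nM) and not as a number.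

Compound 4 (`O=C(Nc1cccc(-c2ccccc2)c1)C(Cl)Cl`) has not yet been measured. It differs from compound 3 in one place, with hydrogen in place of trifluoromethyl on an aromatic carbon of a six-membered aromatic ring of carbon only. No measured pair of these compounds differs in a single place, so the size of this change has no direct precedent here. The readings of compound 1 (9860 nM) and compound 3 (18500 nM) sit close together, so no step beyond the scatter is expected in this assay for this change. The step of a 1.1-fold higher number from compound 3 to compound 4 (0.03 log units; within the scatter) is accordingly expected to stay within the scatter. The estimated value for compound 4 is 20000 nM with an expected range (from 8000 nM to 50000 nM).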

Compound 4, half-maximal inhibitory concentration: 8900 nM
Compound 4: middle estimate off by 2.2-fold (0.35 log units), on the high side; measured number inside the range.
By their numbers in this assay, from the lowest: compounds 4, 1 and 3 (each within the scatter of the next, the first and the last beyond it). At a limit, above all of these: compound 2.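

In this assay, hydrogen in place of trifluoromethyl on this aromatic carbon gives a 2.1-fold lower number from compound 3 to compound 4 (0.32 log units; beyond the scatter), the first direct measure of this change, and it shows that the trifluoromethyl group of compound 3 brings no gain here, while hydrogen in place of methyl gives a 1.1-fold lower number from compound 1 to compound 4 (0.04 log units; within the scatter), which leaves that pair indistinguishable. For the compounds shown here, exchanging the ring itself is a different matter: phenyl in place of thiophen-3-yl gives an at least 5.6-fold lower number from compound 2 to compound 4 (0.74 log units; beyond the scatter), the only step here whose reading reaches past the modest range, and it places the unsubstituted phenyl ahead of the thiophen-3-yl ring. Compound 2 is reported only as a limit, so this step is a bound and not a measured size: the limit of > 50000 nM in this assay, at which 1 of the 4 values shown sits.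

The compounds shown cover only hydrogen, methyl and trifluoromethyl on the phenyl ring, so it remains open how an amine, a carboxylic acid or a methoxy group on this same aromatic carbon would read. The dichloroacetamide end of the shared core stays the same throughout, so what a longer chain there would do is also left open.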